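The source may hold more compounds than are shown below. What is called first, only, known or untested is meant among the compounds shown, and "the series" means these compounds.

Compound 1, with structure `Cc1ccc2nc(NCCCCOc3cc(O)c4c(=O)cc(-c5ccccc5)oc4c3)sc2c1`, gives 6.56 ug/mL in a functional assay on HeLa cells (Homo sapiens) for cytotoxicity, read by sulforhodamine B assay, with a stated time of 48 h; a higher number here means a weaker inhibitor, a lower number a stronger inhibitor. Compound 2, with structure `O=c1cc(-c2ccccc2)oc2cc(OCCCCNc3nc4ccc(Br)cc4s3)cc(O)c12`, gives 6.56 ug/mL in this assay; the step of no change at the digits printed from compound 1 to compound 2 (within the scatter) shows that the two compounds sit level. Compound 3, with structure `O=c1cc(-c2ccccc2)oc2cc(OCCCCNc3nc4c(F)cc(F)cc4s3)cc(O)c12`, has not yet been measured in this assay. It differs from compound 1 by 4,6-difluoro-1,3-benzothiazol-2-yl in place of 6-methyl-1,3-benzothiazol-2-yl on an amine nitrogen. Among the compounds with values here, the only measured step that bears on this change is no change at the digits printed from compound 1 to compound 2 (within the scatter), where a different substituent on the same aromatic carbon left the value where it was. On that basis the expected step of a 1.0-fold lower number from compound 1 to compound 3 (0.00 log units; within the scatter) is small, in no particular direction. Compound 3 is therefore expected to give about 6.5 ug/mL in this assay, with a range from 3 ug/mL to 14 ug/mL.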

Compound 3, half-maximal inhibitory concentration: 5.56 ug/mL
For compound 3 the middle estimate is 1.2-fold (0.07 log units) above the measured one; measured number inside the range.
By their numbers in this assay, from the lowest: compounds 3, 1 and 2 (each within the scatter of the next).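

In this assay, replacing the 6-methyl-1,3-benzothiazol-2-yl on the amine nitrogen with 4,6-difluoro-1,3-benzothiazol-2-yl gives a 1.2-fold lower number from compound 1 to compound 3 (0.07 log units; within the scatter) and replacing the 6-bromo group of compound 2 in the same way gives a 1.2-fold lower number from compound 2 to compound 3 (0.07 log units; within the scatter) so the two fluorines also leave the reading level. The earlier pair showed this only for one substituent exchanged for another, whereas compound 3 carries a different pattern of substituents and the cytotoxicity reading still holds across all three groups. Nothing measured here explains why these groups read alike.

From the compounds shown here alone, whether the reading would hold with an amine or a carboxylic acid on the benzothiazole stays open, as does the effect of a longer chain to the shared core. An unsubstituted 1,3-benzothiazol-2-yl also remains an open comparison.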